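This account rests on a few compounds, and the source may have more. Where it says the series, first, only, none or still open, it means among the compounds named here.

Compound 1 `Cc1ccc(S(=O)(=O)N2CC[C@@H](Br)C[C@@H]2CC(C)C)cc1` is the starting point: in a functional assay on WiDr cells (Homo sapiens) for antiproliferative activity, read by sulforhodamine B assay, with a stated time of 48 h (a higher number here means a weaker inhibitor of growth, a lower number a stronger inhibitor of growth), compound 1 gives 14000 nM. Compound 2 `CCCCCCC[C@H]1C[C@H](Br)CCN1S(=O)(=O)c1ccc(C)cc1` carries hexyl in place of isopropyl on a saturated chain carbon bound to a saturated ring carbon. In this assay compound 2 reaches only a limit, > 100000 nM. The step of an at least 7.1-fold higher number from compound 1 to compound 2 (0.85 log units; beyond the scatter) is thus at least modest, and its size is bounded by the limit of > 100000 nM in this assay, at which 1 of the 3 values shown sits.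

Compound 3 `Cc1ccc(S(=O)(=O)N2CCC(Br)=CC2CC(C)C)cc1` has a different core; how the two cores differ is not broken down here. In this assay compound 3 gives 16000 nM, which sits within the scatter of the value of compound 1.

Compound 4 `CCCCCCCC1C=C(Br)CCN1S(=O)(=O)c1ccc(C)cc1` is not yet measured and differs from compound 3 by hexyl in place of isopropyl on a saturated chain carbon bound to a saturated ring carbon, the same change that separated compound 1 from compound 2. On the strength of an at least 7.1-fold higher number from compound 1 to compound 2 (0.85 log units; beyond the scatter) a step of similar size is expected, a 7.5-fold higher number from compound 3 to compound 4 (0.88 log units; beyond the scatter), and the value may again come back as a limit. Compound 4 is estimated at 120000 nM, expected between 40000 nM and 400000 nM.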

Compound 4, concentration for 50% growth inhibition: 40000 nM
Beside the measured number, compound 4's estimate is 3.0-fold (0.48 log units) above it; the measured number falls inside the stated range.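

The change from isopropyl to hexyl again gives a weaker inhibitor of growth in this assay, with a 2.5-fold higher number from compound 3 to compound 4 (0.40 log units; beyond the scatter), so the direction seen on the core of compound 1 holds on the core of compound 3. The size of the step does not carry over unchanged: the same change on two cores in this assay, an at least 7.1-fold higher number (0.85 log units; beyond the scatter) from compound 1 to compound 2 and a 2.5-fold higher number (0.40 log units; beyond the scatter) from compound 3 to compound 4, at least 2.8-fold (0.45 log units) apart, beyond the scatter of two such steps. On these data alone, compound 2 gives > 100000 nM, which is a limit, so the true size of the gap stays unknown, and two cores do not show how the change would behave on a third.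

The compounds shown leave open whether an intermediate chain such as butyl would follow the same course. They also leave open how a chain ending in an amine or a carboxylic acid would compare with hexyl on either core.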